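A few compounds are considered here, and "the series" means these few. Any claim that something is new, unique, unknown or untested is made for them only; others in the source may bear on it.

Measured in an ADME assay on HEp-2 cells (Homo sapiens) for cytotoxicity; a lower number here means that less compound is tolerated, a higher number that more compound is tolerated:
compound 1 `C=C(C)n1c(=O)n(Cc2nc3ccccc3n2CCC(C)C)c2ccccc21`: 24600 nM
compound 2 `CC(=O)NCc1ccc2c(c1)nc(Cn1c(=O)n(C(C)C)c3ccccc31)n2CCC(C)C`: 178000 nM
compound 3 `C=C(C)n1c(=O)n(Cc2nc3cc(C(=N)N)ccc3n2CCC(C)C)c2ccccc21`: 10800 nM

Compound 3 has the lowest number of the three, with compound 1 the nearest and compound 2 the furthest. The next compound is compound 4 `CC(C)CCn1c(Cn2c(=O)n(CC(=O)OC(C)(C)C)c3ccccc32)nc2cc(C(=N)N)ccc21`, which carries (tert-butoxycarbonyl)methyl in place of 1-methylethenyl on an aromatic nitrogen.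

For the measured compounds named here, the only measured step is a 2.3-fold lower number from compound 1 to compound 3 (0.36 log units; beyond the scatter). Going by the values given here, it was a modest step on an aromatic carbon, so no measured step covers a change on this nitrogen. Compound 2, at 178000 nM, has another group on this nitrogen but also differs elsewhere, so its value cannot be tied to that group. With so little to go on, only a small move towards a higher number in this assay is expected, probably not beyond the scatter. The expected change is a 1.4-fold higher number from compound 3 to compound 4 (0.14 log units; within the scatter). For compound 4 the estimate is 15000 nM, with an expected range of 5000 nM to 50000 nM.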

Compound 4, half-maximal cytotoxic concentration: 7900 nM
Estimate against measurement, compound 4: 1.9-fold (0.28 log units) above; the range from low to high includes it.
By their numbers in this assay, from the lowest: compounds 4 and 3 (each within the scatter of the next); then compound 1; then compound 2.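

In this assay, the aromatic nitrogen now has a measured step of its own: a 1.4-fold lower number from compound 3 to compound 4 (0.14 log units; within the scatter). Here (tert-butoxycarbonyl)methyl, with 2 hydrogen-bond acceptors, replaces 1-methylethenyl, with 0 hydrogen-bond acceptors, and this pair stays within the scatter, so on this one pair the larger group leaves the number in this assay unresolved from that of the smaller one. No available evidence bears on this result.

As far as these compounds go, it remains open whether a carboxylic acid, an amine or a longer alkyl chain on this nitrogen would also stay within the scatter of compound 3. From the compounds shown here alone, whether the same exchange would read alike on the core of compound 1 is also open.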